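The source may report more compounds than this note shows. Statements on the series, on what has been measured and on what is new or still open speak of the compounds shown alone.

Measured in a functional assay on the whole organism with Rattus norvegicus as the target; a lower number here means that less compound is needed, a higher number that more compound is needed for the effect:
Compound 1 `CCOCCOC(=O)C(=O)Nc1nc(-c2cc(Br)no2)cs1`: > 30 mg/kg (a limit)
Compound 2 `CCOCCOC(=O)C(=O)Nc1nc(-c2cc(OC)no2)cs1`: 11 mg/kg
Compound 3 `CCOCCOC(=O)C(=O)Nc1nc(-c2cc(C)on2)cs1`: 2 mg/kg

Compound 3 holds the lowest number in this set, and a 5.5-fold lower number from compound 2 to compound 3 (0.74 log units; beyond the scatter) lies beyond the scatter. The value of compound 1 is a limit, so it gives no exact number for comparison.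

Compound 4 `CCOCCOC(=O)C(=O)Nc1nc(-c2cc(-c3ccccc3)on2)cs1` carries phenyl in place of methyl on an aromatic carbon, next to the ring oxygen (phenyl in place of methyl on an aromatic carbon). Among the measured compounds shown here, no measured step makes this exact exchange. The nearest evidence is indirect: an at least 2.7-fold lower number from compound 1 to compound 2 (0.43 log units; beyond the scatter) and the large at least 15-fold lower number from compound 1 to compound 3 (1.17 log units; beyond the scatter) show that this assay responds to changes in the group carried on the core. With compound 3 already at 2 mg/kg, a modest move towards a higher number seems more likely than a further fall, though the direction is uncertain. The expected change is a 3.0-fold higher number from compound 3 to compound 4 (0.48 log units; beyond the scatter). For compound 4, the estimated value is 6 mg/kg, with an expected range from 1.5 mg/kg to 25 mg/kg.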

Compound 4, dose for half-maximal effect: 13 mg/kg
Estimate against measurement, compound 4: 2.2-fold (0.34 log units) below, and the stated range covers the measured number.
By their numbers in this assay, from the lowest: compound 3; then compounds 2 and 4 (each within the scatter of the next). At a limit, above all of these: compound 1.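

Phenyl in place of methyl, on the aromatic carbon next to the ring oxygen, gives a 6.5-fold higher number from compound 3 to compound 4 (0.81 log units; beyond the scatter) in this assay. Among the compounds shown here, the earlier steps changed the group at another ring position or changed the arrangement of the ring itself, so this is the first step that reads this position alone, and here methyl is the better of the two groups. With phenyl at this carbon the number remains an exact one, and only compound 1 sits at a limit: the limit of > 30 mg/kg in this assay, at which 1 of the 4 values shown sits.

The compounds shown give just two groups at this carbon, methyl and phenyl, so they cannot tell whether the trend depends on the number of heavy atoms or on the aromatic ring. On these data alone, how an ethyl group, an amine or a carboxylic acid would read here remains open.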